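This account rests on a few compounds, and the source may have more. Where it says the series, first, only, none or still open, it means among the compounds named here.

Measured in a physicochemical assay on cells (Homo sapiens), with a stated time of 18 h, tested at 10 uM; on this read-out higher numbers stand for a weaker effect at the one concentration tested and lower numbers for a stronger effect:

Compound 1 `COc1cc(/C=N/NC(=O)c2ccncc2)cc(OC)c1O`: 7%
Compound 2 `COc1cc(/C=N/NC(=O)OCc2ccccc2)cc(OC)c1O`: 3%
Compound 3 `COc1cc(/C=N/Nc2nc3ccccc3s2)cc(OC)c1O`: 3%

All three compounds share one core and differ only in the group attached to the far nitrogen of the hydrazone. Compound 3 stands level with compound 2 at the digits reported, and the two together are the lowest of the three numbers. Compound 1 is the furthest away, yet its gap to compound 3 lies within the scatter of repeated measurements, so the three compounds cannot be told apart on these values.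

The next compound, compound 4 `COc1cc(/C=N/N(C)c2nc3ccccc3s2)cc(OC)c1O`, keeps the whole of compound 3 and changes one point: methyl in place of hydrogen on a nitrogen on an aromatic ring. The hydrogen that leaves is the one on the hydrazone nitrogen carrying the aromatic ring.

Among the compounds with values here, only one step between measured compounds is available, a number 4 percentage points lower from compound 1 to compound 2 (within the scatter), and it concerns the group on a carbonyl carbon, a different place from the nitrogen altered here. Within the data shown here, no measured pair touches the nitrogen-bound hydrogen, so there is no direct guide to the size of this step. Among the measured compounds shown here, with every value so far sitting low and close together, the step of a number 5 percentage points higher from compound 3 to compound 4 (within the scatter) is expected to stay within the scatter. Compound 4 is therefore estimated at 8%, with a range from 0% to 35%, the width reflecting the absence of any measured change at this nitrogen.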

Compound 4, a percentage reported as activity, at one concentration (the size of the read-out at that concentration, not a potency): 3%
Compound 4: the middle estimate sits 5 percentage points above what was measured; low and high end bracket the measured number.
By their numbers in this assay, from the lowest: compounds 2, 3, 4 and 1 (each within the scatter of the next).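

Adding methyl in place of hydrogen on the nitrogen on an aromatic ring gives no change at the digits printed from compound 3 to compound 4 (within the scatter) in this assay, the first measured change at this position, as the only earlier step concerned the group on a carbonyl carbon. The hydrogen on this nitrogen can therefore be swapped for methyl, which adds one carbon and no ring, without moving this read-out outside the usual scatter at the one concentration tested, so this read-out shows no dependence on that hydrogen being present. Nothing available explains why the number holds steady across this swap.

As far as these compounds go, whether the same holds for something larger on this nitrogen, such as a longer chain like propyl, a benzyl group or a chain ending in a carboxylic acid, remains open. From the compounds shown here alone, a value at one concentration gives the size of the read-out there and not a potency, so it also remains open whether compound 3 and compound 4 would separate at other concentrations.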